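The source may report more compounds than this note shows. Statements on the series, on what has been measured and on what is new or still open speak of the compounds shown alone.

In a physicochemical assay for lipophilicity (on this read-out higher numbers stand for higher lipophilicity and lower numbers for lower lipophilicity), the measured compounds stand as follows:

compound 1 `CCC(=O)Oc1c(OC)c(OC)c(OC(=O)CC)c2ccccc12`: 3.44
compound 2 `COc1c(OC)c(OC(=O)C(C)C)c2ccccc2c1OC(=O)C(C)C`: 4.61
compound 3 `CCC(=O)Oc1c(OC)c(OC)c(OC(=O)CC)c2c(C)cccc12`: 3.9

Compound 4 `COc1c(OC)c(OC(=O)C(C)C)c2c(C)cccc2c1OC(=O)C(C)C` has not yet been measured in this assay.

Among the compounds with values here, the one change that has been measured is methyl in place of hydrogen on an aromatic carbon, which gave a number 0.46 log units higher from compound 1 to compound 3 (beyond the scatter). Compound 2 differs from compound 1 in more than one place, and the difference between the two cores is not broken down here. In this assay compound 2 lies highest of the three, beyond the scatter above both compound 3 and compound 1.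

Compound 4 carries the same change relative to compound 2: methyl in place of hydrogen on an aromatic carbon. The place description matches that of the earlier change word for word, so the change is taken as the same. The step from compound 2 to compound 4 in this assay is therefore expected to be about a number 0.44 log units higher from compound 2 to compound 4 (beyond the scatter). This rests on compound 3 alone, because the same change gave a number 0.46 log units higher from compound 1 to compound 3 (beyond the scatter) there, and a single instance is a narrow basis. Compound 4 is estimated at 5.05, with a range from 4.7 to 5.4.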

Compound 4, partition coefficient: 5
Compound 4: middle estimate off by 0.05 log units, on the high side, within the range that was stated.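

In this assay, methyl in place of hydrogen on an aromatic carbon gave a number 0.39 log units higher from compound 2 to compound 4 (beyond the scatter), while on the core of compound 1 the same change gave a number 0.46 log units higher from compound 1 to compound 3 (beyond the scatter), so both steps are modest and point the same way. Within the data shown here, the change therefore carried over from one core to the other in direction and in its modest size, but these two pairs cover only two cores and one place, and they give no general rule for the series. Nothing shown accounts for the step or ties it to any property of the methyl group.

Still open, on these data alone, is whether an ethyl group, an amine or a carboxylic acid in place of that hydrogen would give a step of the same direction on both cores. Also open, as far as these compounds go, is whether methyl on another carbon of the same ring would repeat these steps in this assay.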